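Biaryl amide series: phenyl to pyridin-2-yl

The source may hold more compounds than are shown below. What is called first, only, known or untested is meant among the compounds shown, and "the series" means these compounds.

Measured so far:
compound 1, `CNC(=O)N1CCCc2ccc(NC(=O)c3ccc(-c4ccccc4)cc3)cc21` — 74.3%
compound 2, `CNC(=O)N1CCCc2ccc(NC(=O)c3cccc(-c4cnn(S(C)(=O)=O)c4)c3)cc21` — 18%

In a functional assay on MV4-11 cells (Homo sapiens) for antiproliferative activity, with a stated time of 6 days, tested at 6.25 uM (on this read-out higher numbers stand for a stronger effect at the one concentration tested and lower numbers for a weaker effect), compound 1 gives 74.3%, the higher of the two numbers. Going by the values given here, compound 2 gives 18%, a gap beyond the scatter, but its structure differs from compound 1 in more than one place, so no single step is read from it.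

Compound 3, `CNC(=O)N1CCCc2ccc(NC(=O)c3ccc(-c4ccccn4)cc3)cc21`, is not yet measured. Its change from compound 1 is pyridin-2-yl in place of phenyl on an aromatic carbon. Among the compounds with values here, no step of this kind has been measured, so the direction rests on the change alone. For compound 3 a small loss is expected, a number 19.3 percentage points lower from compound 1 to compound 3 (beyond the scatter), likely close to the scatter. Compound 3 is estimated at 55%, in the range 25% to 80%.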

Compound 3, a percentage reported as inhibition, at one concentration (the size of the read-out at that concentration, not a potency): 79.2%
Compound 3: middle estimate off by 24.2 percentage points, on the low side; measured number inside the range.
By their numbers in this assay, from the lowest: compound 2; then compounds 1 and 3 (each within the scatter of the next).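

In this assay, pyridin-2-yl in place of phenyl, on an aromatic carbon para to a large group, gives a number 4.9 percentage points higher from compound 1 to compound 3 (within the scatter). Going by these compounds alone, this is the first single-place step, and it shows that this position accepts a ring nitrogen, and with it one hydrogen-bond acceptor, with no change beyond the scatter. Nothing available accounts for this result.

Still open, as far as these compounds go, is whether pyridin-3-yl, or a ring carrying an amine or a carboxylic acid, behaves the same way at this position. A read-out at one concentration also leaves any potency difference between compound 1 and compound 3 unresolved.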